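A simple amide swap on a biaryl sulfonic acid scaffold

A few compounds are considered here, and "the series" means these few. Any claim that something is new, unique, unknown or untested is made for them only; others in the source may bear on it.

Compound 2 `O=C(Nc1ccc(-c2ccc(C(=O)Nc3cccc4cccc(S(=O)(=O)O)c34)cc2)cc1)c1ccc2[nH]nnc2c1` gives the highest number of the two measured compounds in an assay on isolated protein for inhibition of CD40-CD40L (Homo sapiens), read by ELISA, with a stated time of 1 h (on this read-out higher numbers stand for weaker inhibition and lower numbers for stronger inhibition), at 990 nM; its nearest neighbour is compound 1 `COC(=O)c1ccc(C(=O)Nc2ccc(-c3ccc(C(=O)Nc4cccc5cccc(S(=O)(=O)O)c45)cc3)cc2)cc1`, which gives 170 nM. Compound 3 `Nc1ccc(C(=O)Nc2ccc(-c3ccc(C(=O)Nc4cccc5cccc(S(=O)(=O)O)c45)cc3)cc2)cc1` carries a group of 7 heavy atoms (6 carbon, 1 nitrogen; one six-membered aromatic ring of carbon only) in place of a group of 9 heavy atoms (6 carbon, 3 nitrogen; one five-membered aromatic ring with 3 hetero atoms, one six-membered aromatic ring of carbon only), on a carbonyl carbon. For the measured compounds named here, the only step that bears on this is the one a 5.8-fold higher number from compound 1 to compound 2 (0.77 log units; beyond the scatter), in which the same carbonyl position was changed in the opposite sense. Reversing that kind of change is expected to lower the number by a modest amount, a 4.0-fold lower number from compound 2 to compound 3 (0.60 log units; beyond the scatter). Compound 3 is therefore estimated at 250 nM, within 80 nM to 800 nM.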

Compound 3, half-maximal inhibitory concentration: 301000 nM
Beside the measured number, compound 3's estimate is 1200-fold (3.08 log units) below it, and the stated range ends below it.
By their numbers in this assay, from the lowest: compound 1; then compound 2; then compound 3.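

In this assay this carbonyl position proves far more sensitive than the earlier modest step suggested, with a 300-fold higher number from compound 2 to compound 3 (2.48 log units; beyond the scatter) when 4-aminophenyl enters. Amino in place of methoxycarbonyl on an aromatic carbon gives a 1800-fold higher number from compound 1 to compound 3 (3.25 log units; beyond the scatter) and so sets 4-aminophenyl well apart from both other groups. Nothing measured here accounts for this large loss. The compounds shown leave open whether the loss follows the amino group itself or extends to other groups on that aromatic carbon, such as a carboxylic acid or an acetylamino group.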